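The source may hold more compounds than are shown below. What is called first, only, known or untested is meant among the compounds shown, and "the series" means these compounds.

Compound 1 `CC(C)(C)c1ccc(C(=O)N/N=C/c2ccc([N+](=O)[O-])o2)cc1`: > 200000 nM
Compound 2 `O=C(N/N=C/c1ccc([N+](=O)[O-])o1)C1CCCCC1`: > 200000 nM

Both results shown are limits of an ADME assay on LL24 cells (Homo sapiens) for inhibition, read by MTT assay, with a stated time of 24 h (on this read-out lower numbers stand for stronger inhibition and higher numbers for weaker inhibition), rather than numbers. For compound 1 the figure > 200000 nM is such a limit. For compound 2 the figure > 200000 nM is likewise a limit. Compound 1 thus stands at the limit of this assay, and every value shown sits there too (the limit of > 200000 nM in this assay, at which 2 of the 2 values shown sit). No step between two measured compounds is shown, so no measured step can guide the next change.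

Compound 3 `CCCOc1ccc(C(=O)N/N=C/c2ccc([N+](=O)[O-])o2)cc1` differs from compound 1 by propoxy in place of tert-butyl on an aromatic carbon. The data give no basis for expecting a change beyond the usual scatter in this assay. Because compound 1 sits at the limit > 200000 nM, compound 3 is expected to give an equally weak result, and the expected step is a step that the limit leaves unreadable from compound 1 to compound 3. Compound 3 is estimated at 300000 nM, with a range from 100000 nM to 1000000 nM, most likely reported again only as a limit.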

Compound 3, half-maximal inhibitory concentration: > 200000 nM
Compound 3 gave a limit, no number; the forecaster's own chance of this, stated with the estimate: 85%; the middle value does not contradict the limit.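

Compound 1 and compound 3 each give only a limit in this assay, so no step between them can be read: the limit of > 200000 nM in this assay, at which 3 of the 3 values shown sit.

The compounds shown leave open how strongly any of them inhibits, and whether propoxy in place of tert-butyl changes anything in this assay.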